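Lipophilicity notes: bromophenyl for methylphenyl on the amine nitrogen

The source may hold more compounds than are shown below. What is called first, only, known or untested is meant among the compounds shown, and "the series" means these compounds.

Measured so far:
compound 1 `COc1ccc(NC(=O)Nc2ccc(NC3=NS(=O)(=O)c4ccccc43)cc2)cc1`: 2.99
compound 2 `Cc1ccc(NC2=NS(=O)(=O)c3ccc(NC(=O)CCC(=O)O)cc32)cc1`: 1

In a physicochemical assay for lipophilicity (on this read-out lower numbers stand for lower lipophilicity and higher numbers for higher lipophilicity), compound 1 gives 2.99, and compound 2 gives 1. Compound 2 is thus the lower of the two, well apart from compound 1. Compound 3 `O=C(O)CCC(=O)Nc1ccc2c(c1)C(Nc1cccc(Br)c1)=NS2(=O)=O` has not yet been measured. It differs from compound 2 by 3-bromophenyl in place of 4-methylphenyl on an amine nitrogen. Within the data shown here, no measured pair carries this change, so the expectation rests on compound 2 alone. A small upward step is expected, a number 0.30 log units higher from compound 2 to compound 3 (within the scatter), at the edge of the usual scatter of this assay. For compound 3 the estimate in this assay is 1.3, with a range of 0.8 to 1.8.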

Compound 3, partition coefficient: 1.26
Beside the measured number, compound 3's estimate is 0.04 log units above it; measured number inside the range.
By their numbers in this assay, from the lowest: compounds 2 and 3 (each within the scatter of the next); then compound 1.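

At this amine nitrogen, 3-bromophenyl in place of 4-methylphenyl gives a number 0.26 log units higher from compound 2 to compound 3 (within the scatter) in this assay, the first step read at this position. On this read-out, the two groups cannot be told apart, even though the change moves the substituent and swaps methyl for bromine. No supporting measurement bears on this step.

Because both changes come in one step, the contribution of each stays unresolved. Also open, on these data alone, is whether an aminomethyl group or a longer alkyl chain on the phenyl ring at this nitrogen would separate from compound 2.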